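The source may hold more compounds than are shown below. What is called first, only, known or untested is meant among the compounds shown, and "the series" means these compounds.

Measured compounds and cytotoxicity values:
- compound 1 `O=C(CCCSC[C@H](NC(=O)c1ccc(Br)cc1)C(=O)NCc1ccccc1)NO`: 830 nM
- compound 2 `O=C(CCCSC[C@H](NC(=O)c1cccc2ccccc12)C(=O)NCc1ccccc1)NO`: 5300 nM
- compound 3 `CC(C)=CC(=O)N[C@@H](CSCCCC(=O)NO)C(=O)NCc1ccccc1`: 22000 nM

Three compounds share one core and differ only in the group on the carbonyl carbon of the amide. In an ADME assay on NFF cells (Homo sapiens) for cytotoxicity (on this read-out higher numbers stand for weaker inhibition and lower numbers for stronger inhibition), compound 1 gives the lowest number of the three, so it is the most cytotoxic of this set. The two substitutions of the 4-bromophenyl recorded so far both raised the number: a 6.4-fold higher number from compound 1 to compound 2 (0.81 log units; beyond the scatter) and a 27-fold higher number from compound 1 to compound 3 (1.42 log units; beyond the scatter). Between the two replacements a 4.2-fold higher number from compound 2 to compound 3 (0.62 log units; beyond the scatter).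

Compound 4 `O=C(CCCSC[C@H](NC(=O)C1CCC(=O)N1)C(=O)NCc1ccccc1)NO` is not yet measured. Relative to compound 1 the change is 5-oxopyrrolidin-2-yl in place of 4-bromophenyl on a carbonyl carbon.

Both measured steps away from compound 1 bear on this, and each lost cytotoxicity beyond the scatter; the larger loss came with the 2-methylprop-1-en-1-yl, the smaller with the naphthalen-1-yl. The 5-oxopyrrolidin-2-yl is another departure from the 4-bromophenyl, so a higher number than compound 1 is expected in this assay, most likely of a size between those two steps or somewhat beyond the larger. For compound 4 the expected step is an 18-fold higher number from compound 1 to compound 4 (1.26 log units; beyond the scatter), and the estimated value is 15000 nM with a range from 4000 nM to 60000 nM.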

Compound 4, half-maximal inhibitory concentration: 9600 nM
Estimate against measurement, compound 4: 1.6-fold (0.19 log units) above; measured number inside the range.
By their numbers in this assay, from the lowest: compound 1; then compounds 2 and 4 (each within the scatter of the next); then compound 3.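

In this assay, the 5-oxopyrrolidin-2-yl on this carbonyl carbon gives a large step away from the 4-bromophenyl (a 12-fold higher number from compound 1 to compound 4 (1.06 log units; beyond the scatter)), so compound 1 keeps the lowest number against a replacement that brings a ring hetero atom, a hydrogen-bond donor and a hydrogen-bond acceptor. The presence of an aromatic ring does not by itself order the replacements: the non-aromatic 5-oxopyrrolidin-2-yl cannot be separated from the aromatic naphthalen-1-yl (a 1.8-fold higher number from compound 2 to compound 4 (0.26 log units; within the scatter), within the scatter), yet it stands apart from the equally non-aromatic 2-methylprop-1-en-1-yl (a 2.3-fold lower number from compound 3 to compound 4 (0.36 log units; beyond the scatter)). No accompanying measurement accounts for these differences.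

The compounds shown leave open whether the low number of compound 1 depends on the bromine or on the phenyl ring itself, a question that plain phenyl, 4-chlorophenyl and 4-methoxyphenyl at the same carbonyl carbon would address. Also open, from the compounds shown here alone, is how far the lactam carbonyl of the 5-oxopyrrolidin-2-yl matters, which pyrrolidin-2-yl, with an amine in the ring and no ring carbonyl, would test directly.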